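Working notes: step from compound 3 to compound 4

The source may hold more compounds than are shown below. What is called first, only, known or untested is meant among the compounds shown, and "the series" means these compounds.

Measured compounds:
Compound 1 `COc1ccc(-c2cc(C(=O)/C=C/c3ccc(C)cc3)nc3cc(-c4ccccc4)nn23)cc1OC`: 22200 nM
Compound 2 `COc1cc(-c2cc(/C=C/C(=O)c3ccccc3)nc3cc(-c4ccccc4)nn23)cc(OC)c1OC`: 18200 nM
Compound 3 `COc1ccc(C(=O)/C=C/c2cc(-c3ccc(OC)c(OC)c3)n3nc(-c4ccccc4)cc3n2)cc1`: 11900 nM

All three numbers come from a functional assay on A549 cells (Homo sapiens) for antiproliferative activity, read by MTT assay, with a stated time of 24 h; on this read-out higher numbers stand for weaker inhibition and lower numbers for stronger inhibition. Compound 3 has the lowest of the three numbers, but its gaps to compound 2 and to compound 1 are within the usual scatter, so no order among the three can be claimed. Among the compounds with values here, the only step joining two measured compounds is a 1.9-fold lower number from compound 1 to compound 3 (0.27 log units; within the scatter), and that change concerns the ethenyl-carbonyl portion, not the methoxy group.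

Compound 4 `COc1ccc(-c2cc(/C=C/C(=O)c3ccccc3)nc3cc(-c4ccccc4)nn23)cc1OC` differs from compound 3 by hydrogen in place of methoxy on an aromatic carbon. Within the data shown here, no measured pair isolates this change. Compound 2, which also carries a 2-benzoylethenyl group, gives 18200 nM, but it differs from compound 4 in more than one place. With nothing bearing directly on the change and every measured gap within the scatter, no step beyond the scatter is expected in this assay. Compound 4 is therefore expected at 15000 nM, with a range of 6000 nM to 40000 nM. This estimate means an expected step of a 1.3-fold higher number from compound 3 to compound 4 (0.10 log units; within the scatter).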

Compound 4, half-maximal inhibitory concentration: 10700 nM
Beside the measured number, compound 4's estimate is 1.4-fold (0.15 log units) above it, within the range that was stated.
By their numbers in this assay, from the lowest: compounds 4, 3, 2 and 1 (each within the scatter of the next, the first and the last beyond it).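

In this assay, the change from 4-methoxyphenyl to phenyl, para to a large group, gives (a 1.1-fold lower number from compound 3 to compound 4 (0.05 log units; within the scatter)) and so does not move the number beyond the scatter at this position. Hydrogen in place of methoxy on an aromatic carbon elsewhere in the series gives (a 1.7-fold lower number from compound 2 to compound 4 (0.23 log units; within the scatter)), also within the scatter, while 2-benzoylethenyl in place of (2-(4-methylphenyl)ethenyl)carbonyl gives (a 2.1-fold lower number from compound 1 to compound 4 (0.32 log units; beyond the scatter)), a modest step and the only one here beyond the scatter. No available evidence accounts for these steps.

Going by these compounds, whether an amine or a carboxylic acid at the para position of this phenyl would shift the number beyond the scatter remains open. Also open, on these data alone, is whether a longer chain in place of methoxy would do so.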